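Phenoxy for Phenyl on a Trifluoromethoxy Isatin Core

This account rests on a few compounds, and the source may have more. Where it says the series, first, only, none or still open, it means among the compounds named here.

Measured compounds:
compound 1, `O=C1C(=O)N(Cc2ccc(Br)cc2)c2ccccc21` — 4600 nM
compound 2, `O=C1C(=O)N(Cc2cccc(-c3ccccc3)c2)c2ccc(OC(F)(F)F)cc21` — > 30000 nM

Two measured compounds share the same bicyclic core. Compound 1 carries a bromobenzyl group on its nitrogen and in a functional assay on CHO cells for positive allosteric modulation of muscarinic acetylcholine receptor M5 (Homo sapiens), read by FLIPR and calcium flux, with a stated time of 1 h (on this read-out higher numbers stand for an effect only at larger amounts of compound and lower numbers for an effect already at smaller amounts), compound 1 gives 4600 nM. Compound 2 carries a trifluoromethoxy group on the core and a biphenylmethyl group on the nitrogen; in this assay compound 2 gives > 30000 nM. That value is a limit of the assay and not a number: compound 2 sits at the limit of > 30000 nM in this assay, at which 1 of the 2 values shown sits, so no effect was seen at the highest amount tested.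

Compound 3, `O=C1C(=O)N(Cc2cccc(Oc3ccccc3)c2)c2ccc(OC(F)(F)F)cc21`, has not yet been measured. It differs from compound 2 in a single place: phenoxy in place of phenyl on an aromatic carbon. Among the compounds with values here, no pair of measured compounds shows a step of this kind, so its size in this assay is unknown from these data. Given that compound 2 already sits at the limit of > 30000 nM in this assay, at which 1 of the 2 values shown sits, the expectation is no step beyond the usual scatter; the step from compound 2 to compound 3 is expected to be about a number no higher from compound 2 to compound 3 (the limit leaves the size open). Compound 3 is therefore estimated at 30000 nM, with a range from 8000 nM to 100000 nM, and most likely only a limit will again be reported.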

Compound 3, half-maximal effective concentration: > 30000 nM
Compound 3: only a limit was reported; the forecaster's own chance of this, stated with the estimate: 70%; the middle value lies on the limit itself.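

Compound 2 and compound 3 each give only a limit of the assay in this assay, not a number, so the step between them cannot be read. Both sit at the same ceiling: the limit of > 30000 nM in this assay, at which 2 of the 3 values shown sit.

The compounds shown leave open whether phenoxy in place of phenyl on an aromatic carbon changes the effect at all.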